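A few compounds are considered here, and "the series" means these few. Any claim that something is new, unique, unknown or untested is made for them only; others in the source may bear on it.

Measured so far:
- compound 1, `C=CCN(CC)S(=O)(=O)NC(=O)Nc1c(C(C)C)cccc1C(C)C`: 2100 nM
- compound 2, `CC(C)c1cccc(C(C)C)c1NC(=O)NS(=O)(=O)Nc1c(C(C)C)cccc1C(C)C`: 11000 nM

Two compounds have been run in an assay on liver for inhibition of sterol O-acyltransferase 1 (Rattus norvegicus), using microsomes; a higher number here means a weaker inhibitor, a lower number a stronger inhibitor. Compound 1 gives 2100 nM, and compound 2 gives 11000 nM; the gap between them lies beyond the scatter, so compound 1 stands as the lower of the two numbers in this assay. Both share the same core, a urea attached to a sulfonyl group, and they differ in what sits on the sulfonyl sulfur.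

Compound 3, `CCCCCCOS(=O)(=O)NC(=O)Nc1c(C(C)C)cccc1C(C)C`, is not yet measured. Against compound 1 the change is hexyloxy in place of allyl(ethyl)amino on a sulfonyl sulfur. Going by the values given here, no pair of measured compounds differs in that way, so the size of this step is not known from the series; the single comparison available, between compound 1 and compound 2, concerns a different replacement and gives no direct guide.

The expectation for compound 3 in this assay is a step of a 1.2-fold higher number from compound 1 to compound 3 (0.08 log units; within the scatter), that is, a change not clearly beyond the scatter in either direction. On that basis compound 3 is estimated at 2500 nM in this assay, with a range from 700 nM to 9000 nM.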

Compound 3, half-maximal inhibitory concentration: 27000 nM
Compound 3: the middle estimate sits 11-fold (1.03 log units) below what was measured; the whole stated range lies below it.
By their numbers in this assay, from the lowest: compound 1; then compound 2; then compound 3.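

In this assay the group on a sulfonyl sulfur whose other neighbour is an amide-type nitrogen proves far from interchangeable: with hexyloxy in place of allyl(ethyl)amino, the series shows a 13-fold higher number from compound 1 to compound 3 (1.11 log units; beyond the scatter) and a step beyond the scatter. Neither group carries a ring and their heavy-atom counts are close, so in this pair a large step comes with an exchange of two open-chain groups of similar size, although the exchange alters several features at once: the attachment changes from nitrogen to oxygen, the double bond leaves and the chain lengthens. Nothing available accounts for the step, and the data give no measured property that could be set beside it.

Going by these compounds, what remains open is which of these features carries the step, since a hexylamino group would keep the chain while restoring a nitrogen attachment, and an ethoxy or butoxy group would keep the oxygen while shortening the chain. Diethylamino would likewise show whether the allyl double bond has any part in the value of compound 1, as this single pair cannot separate these contributions.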